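Amino for Hydroxy on the Fused Ring of Compound 3

A few compounds are considered here, and "the series" means these few. Any claim that something is new, unique, unknown or untested is made for them only; others in the source may bear on it.

Of the compounds shown here, three sharing one core have been measured in an assay on isolated protein for antagonist activity at prostaglandin E2 receptor EP1 subtype (Homo sapiens), read by reporter gene assay; a lower number here means a stronger inhibitor, a higher number a weaker inhibitor. Compound 1 `O=C(O)c1csc(-n2nc(-c3ccccc3)c3ccncc32)n1` gives 39 nM, compound 2 `O=C(O)c1csc(-n2nc(-c3ccccc3)c3cc(F)ccc32)n1` gives 80 nM, and compound 3 `O=C(O)c1csc(-n2nc(-c3ccccc3)c3ccc(O)cc32)n1` gives 140 nM, the highest of the three numbers. Compound 3 lies within the scatter of compound 2 and beyond it relative to compound 1. Compound 4 `Nc1ccc2c(-c3ccccc3)nn(-c3nc(C(=O)O)cs3)c2c1` differs from compound 3 in a single place: amino in place of hydroxy on an aromatic carbon. Going by the values given here, no measured pair shows this exchange, so nothing in the data sets its size. One heavy atom replaces one heavy atom, donor and acceptor counts unchanged, and the expected step of a 1.2-fold lower number from compound 3 to compound 4 (0.07 log units; within the scatter) is estimated to stay within the scatter, in no firm direction. Compound 4 is therefore estimated at 120 nM, with a range from 50 nM to 300 nM.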

Compound 4, half-maximal inhibitory concentration: 19 nM
Beside the measured number, compound 4's estimate is 6.3-fold (0.80 log units) above it; measured number below the stated range.
By their numbers in this assay, from the lowest: compound 4; then compound 1; then compounds 2 and 3 (each within the scatter of the next).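

In this assay, amino in place of hydroxy on this aromatic carbon gives a 7.4-fold lower number from compound 3 to compound 4 (0.87 log units; beyond the scatter). The position therefore distinguishes between these two groups, even though each brings one heavy atom, one hydrogen-bond donor and one hydrogen-bond acceptor and no net charge. No measurement available here accounts for the difference. From the compounds shown here alone, it remains open whether a methylamino or acetamido group on the same carbon would keep the lower number. A methoxy group there would show how far the result depends on the hydroxy hydrogen.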